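From Methoxyphenyl to Thiazolyl on the Sulfonyl Sulfur

The source may hold more compounds than are shown below. What is called first, only, known or untested is meant among the compounds shown, and "the series" means these compounds.

compound 1 `COc1cccc(S(=O)(=O)c2ccc(NC(=O)C(C)(O)C(F)(F)F)cc2)c1`: 16000 nM
compound 2 `CC(O)(C(=O)Nc1ccc(S(=O)(=O)c2ccccc2)cc1[N+](=O)[O-])C(F)(F)F`: 7900 nM

Of the compounds shown here, two have been measured in a functional assay (Cavia porcellus) with sulfonylurea receptors; K-ATP channels (Homo sapiens) as the target; a higher number here means a weaker inhibitor, a lower number a stronger inhibitor. Compound 1 gives the highest of the two numbers; compound 2 gives the lower one, and that gap lies beyond the scatter. Compound 3 `CC(O)(C(=O)Nc1ccc(S(=O)(=O)c2cncs2)cc1)C(F)(F)F` has not been measured. It differs from compound 1 in one place: 1,3-thiazol-5-yl in place of 3-methoxyphenyl on a sulfonyl sulfur. Among the compounds with values here, no measured pair shows a change of this kind, so its size is uncertain; the step of a 1.3-fold lower number from compound 1 to compound 3 (0.12 log units; within the scatter) is expected to be small and not clearly beyond the scatter. Compound 3 is therefore estimated at 12000 nM, within a range from 4000 nM to 40000 nM.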

Compound 3, half-maximal inhibitory concentration: 7700 nM
Compound 3: middle estimate off by 1.6-fold (0.19 log units), on the high side; low and high end bracket the measured number.
By their numbers in this assay, from the lowest: compounds 3 and 2 (each within the scatter of the next); then compound 1.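

In this assay, within the data shown here, the first single-place change at this position, 1,3-thiazol-5-yl in place of 3-methoxyphenyl on a sulfonyl sulfur, gives a 2.1-fold lower number from compound 1 to compound 3 (0.32 log units; beyond the scatter). Inhibition at this position therefore does not depend on a six-membered aromatic ring of carbon only, and a five-membered aromatic ring with 2 hetero atoms and fewer heavy atoms serves at least as well here. No available evidence bears on why the number falls.

The compounds shown leave open whether the step comes from the new ring or from losing the methoxy group. They also leave open how a pyridin-3-yl ring on the sulfonyl sulfur would compare.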